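Adding a tert-butyl group to compound 3

The compounds below may be only part of what the source reports. "The series", "measured", "known", "first", "only" and "open" are said of these compounds alone.

Among the measured compounds shown here, compound 3 `COc1ccc(O)c(-c2ncncc2Sc2nccn2C)c1` stands highest of the three numbers measured so far in an ADME assay on MDCK cells (Canis lupus familiaris) for cytotoxicity (on this read-out higher numbers stand for lower toxicity in this test and lower numbers for higher toxicity in this test), with 618000 ug/mL. Its nearest neighbour is compound 2 `Cn1ccnc1Sc1cnc(C(C)(C)C)nc1-c1ccccc1O`, which gives 194000 ug/mL; the furthest is compound 1 `CC(C)(C)c1nccc(-c2ccccc2O)n1`, which gives 16300 ug/mL. Compound 4 `COc1ccc(O)c(-c2nc(C(C)(C)C)ncc2Sc2nccn2C)c1` is the next compound to be measured in this assay. It differs from compound 3 in one place: tert-butyl in place of hydrogen on an aromatic carbon.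

For the measured compounds named here, the only measured step that changes a single group is a 12-fold higher number from compound 1 to compound 2 (1.08 log units; beyond the scatter), which adds a different group to the shared core and says nothing directly about a tert-butyl group. Compound 2 carries a tert-butyl group and compound 3 does not, but the two also differ elsewhere, so their values cannot be read as a single step. Going by the values given here, no measured pair isolates the change from compound 3 to compound 4, and the expectation rests on the absence of any evidence for a shift in either direction.

Compound 4 is therefore expected to give a number close to that of compound 3. The estimated step is a 1.2-fold lower number from compound 3 to compound 4 (0.09 log units; within the scatter), within the scatter. Compound 4 is expected to give 500000 ug/mL, with a range from 200000 ug/mL to 1500000 ug/mL.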

Compound 4, half-maximal cytotoxic concentration: 116000 ug/mL
For compound 4 the middle estimate is 4.3-fold (0.63 log units) above the measured one; the measured number lies below the stated range.
By their numbers in this assay, from the lowest: compound 1; then compounds 4 and 2 (each within the scatter of the next); then compound 3.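

In this assay, among the compounds shown here, tert-butyl in place of hydrogen on the aromatic carbon between two ring nitrogen atoms gives a 5.3-fold lower number from compound 3 to compound 4 (0.73 log units; beyond the scatter) in the one measured pair that isolates this change, so this position is not indifferent to the group it carries, and here the change points towards higher toxicity in this test. The second pair reads methoxy in place of hydrogen on an aromatic carbon with tert-butyl already present and gives a 1.7-fold lower number from compound 2 to compound 4 (0.22 log units; within the scatter) and so, in this pair, the methoxy group brings no difference that stands clear of the usual scatter. No measurement on hand accounts for the size of either step.

The compounds shown carry only hydrogen or tert-butyl at this position, so it remains open whether methyl, a longer chain or an amine there would give a step of similar size or none at all. On these data alone, it also remains open whether the tert-butyl step would have the same size in a compound lacking the methoxy group.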